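This account rests on a few compounds, and the source may have more. Where it says the series, first, only, none or still open, it means among the compounds named here.

In a functional assay on LOX IMVI cells (Homo sapiens) for inhibition, read by sulforhodamine B assay, with a stated time of 48 h (a lower number here means a stronger inhibitor of growth, a higher number a weaker inhibitor of growth), compound 1 (`COc1cc2nc(-c3ccc(C(F)(F)F)cc3)cc(OCCCN3CCCC3)c2cc1OC`) gives 116 nM and compound 2 (`COc1cc2nc(-c3ccc(Cl)cc3)cc(OCCCN3CCCC3)c2cc1OC`) gives 191 nM on the same scale. Within the data shown here, these are the only two numbers so far, and a 1.6-fold higher number from compound 1 to compound 2 (0.22 log units; within the scatter) leaves them inside the scatter of repeat measurements, so neither can be ranked ahead of the other. Compound 3 (`COc1cc2nc(-c3ccc(C(F)(F)F)cc3)cc(OCCCN3CCCCC3)c2cc1OC`) keeps the shared core and the trifluoromethyl group of compound 1 and alters one group only (piperidin-1-yl in place of pyrrolidin-1-yl on a saturated chain carbon, three bonds along the chain from an oxygen on an aromatic ring) so that a 3-(pyrrolidin-1-yl)propyl chain becomes a 3-(piperidin-1-yl)propyl chain. Among the measured compounds shown here, the single measured step swaps trifluoromethyl for chloro on an aromatic carbon, a different place in the molecule, so it bears on this change only indirectly. For the measured compounds named here, no measured pair changes the ring on the chain, which means the data point in no direction, and no step beyond the scatter is expected in this assay here. The estimate therefore starts from compound 1 at 116 nM and stays close to it. The expected change is a 1.1-fold higher number from compound 1 to compound 3 (0.05 log units; within the scatter) by this estimate. For compound 3 the estimated value is 130 nM with an expected range from 60 nM to 280 nM as the likely span.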

Compound 3, concentration for 50% growth inhibition: 162 nM
The estimate for compound 3 lay 1.2-fold (0.10 log units) below the measured number; measured number inside the range.
By their numbers in this assay, from the lowest: compounds 1, 3 and 2 (each within the scatter of the next).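

Among these compounds, the step from a five-membered to a six-membered ring at the end of the chain is the first measured change at this position, and in this assay it gives a 1.4-fold higher number from compound 1 to compound 3 (0.15 log units; within the scatter). Compound 1 and compound 3 therefore cannot be ranked: with the trifluoromethyl group and the shared core held constant, either pyrrolidin-1-yl or piperidin-1-yl can sit on this saturated chain carbon without a step beyond the scatter. Nothing in the available information offers a reason for this result.

These two rings are closely related, so the result says little about how far this position can be changed, and a morpholin-4-yl ring, an open-chain dimethylamino group or a shorter 2-(pyrrolidin-1-yl)ethyl chain could behave differently. Among the compounds shown here, it also remains open whether the piperidin-1-yl ring would give a similar result alongside the chloro group of compound 2, since the change has been seen only with trifluoromethyl on the aromatic ring.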